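This account rests on a few compounds, and the source may have more. Where it says the series, first, only, none or still open, it means among the compounds named here.

Measured compounds:
compound 1 `CCC1CCCN(C(=O)CN2CN(c3ccccc3)C3(CCN(C(=O)c4ccc(C5CCCCC5)cc4)CC3)C2=O)C1` – 2600 nM
compound 2 `O=C(CN1CN(c2ccccc2)C2(CCN(C(=O)c3ccc(C4CCCCC4)cc3)CC2)C1=O)N1CCCCC1` – 1100 nM
compound 3 `CC1(C)CC(OC(=O)CN2CN(c3ccccc3)C3(CCN(C(=O)c4ccc(C5CCCCC5)cc4)CC3)C2=O)CC(C)(C)N1` – 600 nM

In an assay on HEK293 cells for displacement of a labelled ligand from NPC1-like intracellular cholesterol transporter 1 (Homo sapiens) (on this read-out higher numbers stand for weaker inhibition and lower numbers for stronger inhibition), compound 3 carries the lowest of the three numbers. Against compound 1 the step is a 4.3-fold lower number from compound 1 to compound 3 (0.64 log units; beyond the scatter); against compound 2 it is a 1.8-fold lower number from compound 2 to compound 3 (0.26 log units; within the scatter), so compounds 2 and 3 cannot be ordered. Compound 4 `CS(=O)(=O)NCCCNC(=O)CN1CN(c2ccccc2)C2(CCN(C(=O)c3ccc(C4CCCCC4)cc3)CC2)C1=O` changes the same carbonyl carbon: (3-(methanesulfonamido)propyl)amino in place of (2,2,6,6-tetramethylpiperidin-4-yl)oxy on a carbonyl carbon. All steps measured so far sit at this position and all are modest: a 2.4-fold lower number from compound 1 to compound 2 (0.37 log units; beyond the scatter), a 4.3-fold lower number from compound 1 to compound 3 (0.64 log units; beyond the scatter), a 1.8-fold lower number from compound 2 to compound 3 (0.26 log units; within the scatter). Among the measured compounds shown here, a ring-free chain amide at this carbonyl has no measured precedent, so the expectation is a small step, most likely a somewhat higher number, as a 2.0-fold higher number from compound 3 to compound 4 (0.30 log units; within the scatter). Compound 4 is thus expected near 1200 nM, within 400 nM to 3500 nM.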

Compound 4, half-maximal inhibitory concentration: 3800 nM
The estimate for compound 4 lay 3.2-fold (0.50 log units) below the measured number, outside the stated range (above it).
By their numbers in this assay, from the lowest: compounds 3 and 2 (each within the scatter of the next); then compounds 1 and 4 (each within the scatter of the next).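

In this assay, the ring-free (3-(methanesulfonamido)propyl)amino group on this carbonyl carbon gives a 6.3-fold higher number from compound 3 to compound 4 (0.80 log units; beyond the scatter) and a 3.5-fold higher number from compound 2 to compound 4 (0.54 log units; beyond the scatter), so the position does respond to a chain in place of these ring-bearing groups. The absence of a ring does not separate compound 4 from every ring-bearing compound, however: compound 1 goes against that reading, with a 1.5-fold higher number from compound 1 to compound 4 (0.16 log units; within the scatter). No measurement available here accounts for these steps.

The compounds shown leave open whether the steps follow the missing ring or the methanesulfonamido end. A plain propylamino chain, a longer chain or a carboxylic acid at this carbonyl carbon would help separate the two.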